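The source may hold more compounds than are shown below. What is called first, only, known or untested is meant among the compounds shown, and "the series" means these compounds.

Measured compounds in a functional assay on A549 cells (Homo sapiens) for cytotoxicity, read by MTT assay; a higher number here means a weaker inhibitor, a lower number a stronger inhibitor:
compound 1 `N#Cc1c(Nc2ccccc2)c(Cl)c2nc(N)nc(N)c2c1F`: this value is a limit of the assay, > 1000 ug/mL.
compound 2 `COc1ccc(Nc2c(C#N)c(F)c3c(N)nc(N)nc3c2Cl)cc1`: 103 ug/mL.
compound 3 `N#Cc1c(NCc2ccccc2)c(Cl)c2nc(N)nc(N)c2c1F`: 34.1 ug/mL.

Compound 3 holds the lowest of the two numbers in this assay; the gap to compound 2 is the step of a 3.0-fold lower number from compound 2 to compound 3 (0.48 log units; beyond the scatter). From the limit of compound 1 the change is an at least 29-fold lower number from compound 1 to compound 3 (1.46 log units; beyond the scatter), with compound 1 sitting at the limit of > 1000 ug/mL in this assay, at which 1 of the 3 values shown sits.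

Compound 4 `CC(C)(C)Nc1c(C#N)c(F)c2c(N)nc(N)nc2c1Cl` differs from compound 3 by tert-butyl in place of benzyl on a nitrogen on an aromatic ring. Both measured steps that bear on it alter the group on the same nitrogen: an at least 29-fold lower number from compound 1 to compound 3 (1.46 log units; beyond the scatter) and a 3.0-fold lower number from compound 2 to compound 3 (0.48 log units; beyond the scatter), each lowering the number when the group became benzyl. For the measured compounds named here, no measured step removes the ring from that position, so the direction is open. A modest move back toward a higher number is expected, a 2.3-fold higher number from compound 3 to compound 4 (0.37 log units; beyond the scatter), with wide uncertainty. For compound 4 the estimate in this assay is 80 ug/mL, expected between 25 ug/mL and 300 ug/mL.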

Compound 4, half-maximal inhibitory concentration: 313 ug/mL
Estimate against measurement, compound 4: 3.9-fold (0.59 log units) below; measured number above the stated range.
By their numbers in this assay, from the lowest: compound 3; then compound 2; then compound 4. At a limit, above all of these: compound 1.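

In this assay, tert-butyl is the only group shown on this nitrogen without a six-membered aromatic ring, and replacing benzyl with it gives a 9.2-fold higher number from compound 3 to compound 4 (0.96 log units; beyond the scatter), so the low number of compound 3 does not carry over to every carbon group at this position. Presence of an aromatic ring does not set the order alone: compound 4 lies above the 4-methoxyphenyl compound, a 3.0-fold higher number from compound 2 to compound 4 (0.48 log units; beyond the scatter), yet below the phenyl compound, an at least 3.1-fold lower number from compound 1 to compound 4 (0.50 log units; beyond the scatter). The value of compound 1 is a limit of the assay, not a number: the limit of > 1000 ug/mL in this assay, at which 1 of the 4 values shown sits.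

The compounds shown do not separate loss of the ring from the branching of tert-butyl, a question that a straight butyl chain or a cyclohexylmethyl group on this nitrogen would address. As far as these compounds go, how an amine or a carboxylic acid on the benzyl ring would read also remains open.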